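This account rests on a few compounds, and the source may have more. Where it says the series, first, only, none or still open, it means among the compounds named here.

Two compounds share one core and differ only in where a single fluorine sits on the outer phenyl ring. Compound 1 `CC(C)CCc1cn(-c2ccc(NC(=O)Nc3ccccc3F)cc2)nn1` carries a 2-fluorophenyl group, and in an assay for inhibition of ATP-dependent RNA helicase DDX3X (Homo sapiens), read by FRET, with a stated time of 40 min, in the presence of a further agent that is not named here (a lower number here means a stronger inhibitor, a higher number a weaker inhibitor), compound 1 gives 120 nM. Compound 2 `CC(C)CCc1cn(-c2ccc(NC(=O)Nc3cccc(F)c3)cc2)nn1` carries a 3-fluorophenyl group instead, and in this assay compound 2 gives 200 nM. That change produced a 1.7-fold higher number from compound 1 to compound 2 (0.22 log units; within the scatter), so compound 2 holds the higher of the two numbers, with compound 1 nearest and still within the usual scatter of such measurements.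

Compound 3 `CC(C)CCc1cn(-c2ccc(NC(=O)Nc3ccc(F)cc3)cc2)nn1` has not yet been measured. It differs from compound 2 in one place: 4-fluorophenyl in place of 3-fluorophenyl on an amide-type nitrogen. Going by the values given here, the only measured step that bears on this is the one from compound 1 to compound 2, where moving the fluorine to another spot on the same ring gave a change that stayed within the scatter. Shifting the fluorine once more is therefore expected to give a step in this assay of no more than the scatter, in no clear direction, which means a 1.1-fold lower number from compound 2 to compound 3 (0.02 log units; within the scatter). Compound 3 is estimated at 190 nM, with a range from 80 nM to 450 nM.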

Compound 3, half-maximal inhibitory concentration: 1900 nM
Estimate against measurement, compound 3: 10-fold (1.00 log units) below, outside the stated range (above it).
By their numbers in this assay, from the lowest: compounds 1 and 2 (each within the scatter of the next); then compound 3.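

Moving one fluorine around this ring is not always a neutral change. In this assay, 4-fluorophenyl in place of 3-fluorophenyl on an amide-type nitrogen gives a 9.5-fold higher number from compound 2 to compound 3 (0.98 log units; beyond the scatter), although the two groups have the same atoms, and the step from the 2-fluorophenyl group gives a 16-fold higher number from compound 1 to compound 3 (1.20 log units; beyond the scatter), so among these three compounds the 4-fluorophenyl group stands apart, while the 2-fluorophenyl and 3-fluorophenyl groups remain within the scatter of each other. Nothing available here explains why this one placement of the fluorine separates so sharply from the other two, so the result stands as an observation without a reason attached.

The compounds shown leave open whether the weaker result belongs to fluorine in particular or would also appear with another group in its place, such as the 4-chlorophenyl or 4-methoxyphenyl group, and how an unsubstituted phenyl group on the same nitrogen would compare with all three. They also leave open whether the same order of the three fluorophenyl groups would survive on a core carrying a longer chain or an amine in place of the present chain.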